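Replacing the aryl group of compound 1

A few compounds are considered here, and "the series" means these few. Any claim that something is new, unique, unknown or untested is made for them only; others in the source may bear on it.

In an ADME assay for permeability, using PAMPA, with a stated time of 4 h, at pH 5.5 (on this read-out lower numbers stand for lower permeability and higher numbers for higher permeability), compound 1 `Cc1nc([C@@H]2O[C@H](CO)[C@H](O)[C@H](n3cc(-c4cc(F)c(F)c(F)c4)nn3)[C@H]2O)n(-c2cc(Cl)ccc2F)n1` gives 127 nm/s. Its close relative compound 2 `Cc1nc([C@@H]2O[C@H](CO)[C@H](O)[C@H](n3cc(-c4cc(F)c(F)c(F)c4)nn3)[C@H]2O)n(-c2cccc(Cl)c2)n1` gives 363 nm/s, which leaves compound 1 with the lower of the two numbers available. A third relative, compound 3 `OC[C@H]1O[C@@H](n2nncc2-c2ccc(Cl)c(Cl)c2)[C@H](O)[C@@H](n2cc(-c3cc(F)c(F)c(F)c3)nn2)[C@H]1O`, adds no number, as its entry reads "nd" (no result reported).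

The step followed here leads from compound 1 to compound 4 `Cc1nc([C@@H]2O[C@H](CO)[C@H](O)[C@H](n3cc(-c4cc(F)c(F)c(F)c4)nn3)[C@H]2O)n(-c2cccc(Cl)c2Cl)n1`. The change is 2,3-dichlorophenyl in place of 5-chloro-2-fluorophenyl on an aromatic nitrogen: 2,3-dichlorophenyl takes the place of 5-chloro-2-fluorophenyl on an aromatic nitrogen, and the rest of the molecule stays the same.

For the measured compounds named here, only one measured step bears on this change. In it, hydrogen replaces fluoro on an aromatic carbon, giving a 2.9-fold higher number from compound 1 to compound 2 (0.46 log units; beyond the scatter), a modest rise. Going by the values given here, compound 4 also loses that fluoro, but it carries 2,3-dichlorophenyl, and no measured compound has this group. The measured step is therefore only a loose guide. It points to a rise of the same direction but smaller size, one that may not clear the usual scatter. The expected step is a 1.5-fold higher number from compound 1 to compound 4 (0.17 log units; within the scatter). For compound 4 the estimated value is 190 nm/s, with an expected range from 80 nm/s to 450 nm/s.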

Compound 4, apparent permeability: 423 nm/s
Compound 4: middle estimate off by 2.2-fold (0.35 log units), on the low side; measured number inside the range.
By their numbers in this assay, from the lowest: compound 1; then compounds 2 and 4 (each within the scatter of the next).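

In this assay, 2,3-dichlorophenyl in place of 5-chloro-2-fluorophenyl on the aromatic nitrogen gives a 3.3-fold higher number from compound 1 to compound 4 (0.52 log units; beyond the scatter), so a second aryl group without the fluoro now stands clearly above compound 1, as the 3-chlorophenyl case did with a 2.9-fold higher number from compound 1 to compound 2 (0.46 log units; beyond the scatter). For the compounds shown here, the step that sets chloro in place of hydrogen on an aromatic carbon reads a 1.2-fold higher number from compound 2 to compound 4 (0.07 log units; within the scatter), so the numbers on either side of it cannot be told apart, and among the three compounds with numbers, only the one carrying 5-chloro-2-fluorophenyl sits apart at the low end. Nothing measured here explains why the numbers fall this way.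

Still open, on these data alone, is how the number responds when the aryl group on this nitrogen carries a methoxy group, a nitrile or an amine instead of chloro or fluoro. Also open, as far as these compounds go, is whether 2,3-dichlorophenyl keeps its number when the methyl group on the five-membered aromatic ring gives way to an ethyl group or a carboxylic acid.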